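The compounds below may be only part of what the source reports. "The series", "measured", "known", "first", "only" and "open" are said of these compounds alone.

Measured compounds:
Compound 1 `COc1ccc(C2N=C(SCc3ccccc3)NC(C)=C2C(=O)Nc2ccc(F)cc2)cc1OC` in a functional assay on the whole organism (artery, strain albino) with Rattus norvegicus as the target, with a stated time of 120 min, at a dose of 10 mg/kg by the oral route (on this read-out higher numbers stand for more inhibition at the one dose given (going by the name of the read-out) and lower numbers for less inhibition), gives 8.8%.
Compound 2 `CC1=C(C(=O)Nc2ccc(F)cc2)C(c2ccc([N+](=O)[O-])cc2)N=C(SCc2ccccc2)N1` in this assay gives 18%.

For the measured compounds named here, compound 2 has the higher of the two numbers in this assay, the only other being compound 1; the step of a number 9.2 percentage points higher from compound 1 to compound 2 (within the scatter) is within the scatter, so the two numbers are level within it.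

Compound 3 `CC1=C(C(=O)Nc2ccc(F)cc2)C(c2ccc([N+](=O)[O-])cc2)N=C(SCc2cccc(Cl)c2)N1` differs from compound 2 by chloro in place of hydrogen on an aromatic carbon, on the benzylsulfanyl arm of the shared core.

Going by the values given here, the one measured step, a number 9.2 percentage points higher from compound 1 to compound 2 (within the scatter), concerns the aryl group on the saturated ring carbon, not the benzylsulfanyl arm. Among the compounds with values here, no measured pair varies the benzyl group, so nothing speaks to the effect of chloro there. Without such a precedent the step to compound 3 in this assay is expected to be none beyond the scatter, with the estimate anchored on compound 2.

Compound 3 is therefore estimated at 20% in this assay, in a range from 5% to 40%. The implied step, a number 2 percentage points higher from compound 2 to compound 3 (within the scatter), is expected to be within the scatter.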

Compound 3, a percentage reported as inhibition, in the whole organism at one dose (the size of the read-out at that dose, not a potency): 9.8%
Estimate against measurement, compound 3: 10.2 percentage points above; the range from low to high includes it.
By their numbers in this assay, from the lowest: compounds 1, 3 and 2 (each within the scatter of the next).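

For the compounds shown here, on the benzylsulfanyl arm, the first measured change is (3-chlorobenzyl)sulfanyl for benzylsulfanyl, and in this assay it gives a number 8.2 percentage points lower from compound 2 to compound 3 (within the scatter) with the rest of the structure held fixed. This aromatic carbon of the arm therefore takes a chloro without a change that can be told from the scatter, so the pair gives no sign that this substitution either helps or harms inhibition at the one dose given. No measured information on the compounds bears on this result.

Still open, as far as these compounds go, is whether a methoxy group, an amine or a carboxylic acid on the same aromatic carbon, or a hexyl chain in place of the whole benzyl group, would give a step beyond the scatter. With a single substituted arm and a single oral dose in this series, the pair does not settle how far the arm can be changed, and it gives no potency for any of the compounds.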